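A few compounds are considered here, and "the series" means these few. Any claim that something is new, unique, unknown or untested is made for them only; others in the source may bear on it.

Values in a functional assay on MIA PaCa-2 cells (Homo sapiens) for antiproliferative activity, read by MTT assay, with a stated time of 3 days; a higher number here means a weaker inhibitor, a lower number a stronger inhibitor:
- compound 1 `CCCCCCC#Cc1cn(C/C=C/CN2C(=O)c3ccccc3C2=O)c(=O)[nH]c1=O`: 30000 nM
- compound 2 `CCCCc1ccc(C#Cc2cn(C/C=C/CN3C(=O)c4ccccc4C3=O)c(=O)[nH]c2=O)cc1`: 79000 nM
- compound 3 `CCCCC#Cc1cn(C/C=C/CN2C(=O)c3ccccc3C2=O)c(=O)[nH]c1=O`: not yet measured

Of the two measured compounds, compound 2 has the higher number, at 79000 nM. Compound 3 carries butyl in place of 4-butylphenyl on a triple-bonded carbon. Among the compounds with values here, one measured step bears on this, the modest 2.6-fold higher number from compound 1 to compound 2 (0.42 log units; beyond the scatter), which put 4-butylphenyl in place of hexyl. Compound 3 returns to a chain with no ring, so a step of similar size toward a lower number is expected in this assay. The expected change is a 2.3-fold lower number from compound 2 to compound 3 (0.35 log units; beyond the scatter). The estimate for compound 3 is 35000 nM, with an expected range of 15000 nM to 80000 nM.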

Compound 3, half-maximal inhibitory concentration: 77000 nM
Compound 3: the middle estimate sits 2.2-fold (0.34 log units) below what was measured; measured number inside the range.
By their numbers in this assay, from the lowest: compound 1; then compounds 3 and 2 (each within the scatter of the next).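

In this assay, the swap of 4-butylphenyl for butyl on the triple-bonded carbon leaves the number unchanged within the scatter (a 1.0-fold lower number from compound 2 to compound 3 (0.01 log units; within the scatter)), so loss of the ring by itself does not restore the number of compound 1. Among the chains with no ring, the length matters: shortening hexyl to butyl gives a step beyond the scatter (a 2.6-fold higher number from compound 1 to compound 3 (0.41 log units; beyond the scatter)). No data bearing on the cause of either step are available.

Open, as far as these compounds go, is whether an octyl chain lowers the number further than hexyl. Also open, from the compounds shown here alone, is how a terminal amine or carboxylic acid on the chain would behave.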